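A few compounds are considered here, and "the series" means these few. Any claim that something is new, unique, unknown or untested is made for them only; others in the source may bear on it.

Measured compounds in an assay on HEK293 cells for displacement of a labelled ligand from Melanocortin receptor 4 (Homo sapiens); a higher number here means a weaker inhibitor, a lower number a stronger inhibitor: compound 1 `CC(C)C[C@H](N)c1cc(C(F)(F)F)ccc1N1CCN(C(=O)C(C)Cc2ccc(Cl)c(Cl)c2)CC1` gives 120 nM; 1600 nM (2 entries); compound 3 `CC(C)C[C@H](N)c1cc(C(F)(F)F)ccc1N1CCN(C(=O)COc2cccc(Cl)c2)CC1` gives 2600 nM. Compound 2 `CC(C)C[C@H](N)c1cc(C(F)(F)F)ccc1N1CCN(C(=O)CCC(N)=O)CC1` gives only > 10000 nM, which is a limit of the assay and not a number.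

Compound 2 thus stands at the limit among the values shown, with no single number of its own. Compound 4 `COc1ccc(CC(C)C(=O)N2CCN(c3ccc(C(F)(F)F)cc3[C@@H](N)CC(C)C)CC2)cc1F` differs from it by 1-(3-fluoro-4-methoxybenzyl)ethyl in place of 2-carbamoylethyl on a carbonyl carbon. Among the measured compounds shown here, the one measured step that bears on this change is an at least 3.8-fold lower number from compound 2 to compound 3 (0.58 log units; beyond the scatter), where an aromatic group replaced the carbamoyl-bearing chain on the same carbonyl. Compound 1 carries a related aryl-bearing chain on that carbonyl and shows (the several entries of compound 1 in this assay, 120 nM; 1600 nM (2 entries)). Compound 4 is therefore expected to fall clearly inside the measurable range, by an at least 20-fold lower number from compound 2 to compound 4 (1.30 log units; beyond the scatter) in this assay. The estimate for compound 4 is 500 nM, expected to lie between 100 nM and 4000 nM.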

Compound 4, inhibition constant: 200 nM
The estimate for compound 4 lay 2.5-fold (0.40 log units) above the measured number, within the range that was stated.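

In this assay, 1-(3-fluoro-4-methoxybenzyl)ethyl on the carbonyl carbon gives an at least 50-fold lower number from compound 2 to compound 4 (1.69 log units; beyond the scatter). That step starts from a value of compound 2 that is a limit and not a number: the limit of > 10000 nM in this assay, at which 1 of the 4 values shown sits. The same group in place of (3-chlorophenoxy)methyl gives a 13-fold lower number from compound 3 to compound 4 (1.11 log units; beyond the scatter), so the presence of an aromatic ring in the group does not alone set the number at this carbonyl carbon. The compounds shown leave open which part of 1-(3-fluoro-4-methoxybenzyl)ethyl accounts for these steps. They also leave open how a plain benzyl group, or a chain ending in an amine or a carboxylic acid, would read here.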